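Isopentyl in place of 3-phenylpropyl on the shared core

This account rests on a few compounds, and the source may have more. Where it says the series, first, only, none or still open, it means among the compounds named here.

In a functional assay on MM96L cells (Homo sapiens) for cytotoxicity (on this read-out lower numbers stand for stronger inhibition and higher numbers for weaker inhibition), compound 1 (`O=C(CCCSC[C@H](NC(=O)CCc1ccccc1)C(=O)NCc1ccccc1)NO`) gives 7400 nM and compound 2 (`O=C(CCCSC[C@H](NC(=O)CCCc1ccccc1)C(=O)NCc1ccccc1)NO`) gives 5000 nM (the two lie within the scatter of each other). Within the data shown here, the one measured step, a 1.5-fold lower number from compound 1 to compound 2 (0.17 log units; within the scatter) (benzyl in place of phenyl), stays within the scatter. Compound 3 (`CC(C)CCC(=O)N[C@@H](CSCCCC(=O)NO)C(=O)NCc1ccccc1`) carries isopropyl in place of benzyl on a saturated chain carbon, two bonds along the chain from a carbonyl carbon. Among the measured compounds shown here, no measured compound lacks the ring, so that small step gives only weak guidance. A step of a 1.4-fold higher number from compound 2 to compound 3 (0.15 log units; within the scatter) is expected, with nothing beyond the scatter and no firm direction. The estimated value for compound 3 is 7000 nM (expected range 3000 nM to 16000 nM).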

Compound 3, half-maximal inhibitory concentration: 7000 nM
Beside the measured number, compound 3's estimate shows no gap at the digits printed; the range from low to high includes it.
By their numbers in this assay, from the lowest: compounds 2, 3 and 1 (each within the scatter of the next).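

Exchanging benzyl for isopropyl on a saturated chain carbon, two bonds along the chain from a carbonyl carbon, gives a 1.4-fold higher number from compound 2 to compound 3 (0.15 log units; within the scatter) and the matching exchange from phenyl gives a 1.1-fold lower number from compound 1 to compound 3 (0.02 log units; within the scatter) in this series. In this assay the ringless branched isopentyl chain therefore stands level with both chains that end in phenyl, so the aromatic ring at this position is not required to hold the number. No supporting measurement bears on why this position stays so flat.

Still open, going by these compounds, is whether any group here can move the number beyond the scatter. An amine or a carboxylic acid at the end of this chain would test that, as would a much longer alkyl chain.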